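The source may hold more compounds than are shown below. What is called first, only, known or untested is meant among the compounds shown, and "the series" means these compounds.

In a functional assay with Homo sapiens as the target (a lower number here means a stronger inhibitor, a higher number a weaker inhibitor), compound 1 (`CC(C)[C@H](NC(=O)COc1cccc2ccccc12)C(=O)N[C@@H](CC(=O)O)C(=O)COc1cccc(C(F)(F)F)c1`) gives 16600 nM and compound 2 (`CC(C)[C@H](NC(=O)COc1cccc2ccccc12)C(=O)N[C@@H](CC(=O)O)C(=O)COc1ccc(F)cc1F`) gives 17600 nM while compound 3 (`CC(C)[C@H](NC(=O)COc1cccc2ccccc12)C(=O)N[C@@H](CC(=O)O)C(=O)COc1cc(F)ccc1F`) gives 19700 nM on the same scale. These three values lie within the usual scatter of one another, so compound 3 stands level with the other two. Compound 4 (`CC(C)[C@H](NC(=O)COc1cccc2ccccc12)C(=O)N[C@@H](CC(=O)O)C(=O)COc1cc(F)cc(F)c1F`) carries fluoro in place of hydrogen on an aromatic carbon, which turns the 2,5-difluorophenyl of compound 3 into 2,3,5-trifluorophenyl. The measured swaps of that same aryl group bear most directly on this change (a 1.1-fold higher number from compound 1 to compound 2 (0.03 log units; within the scatter)) and (a 1.2-fold higher number from compound 1 to compound 3 (0.07 log units; within the scatter)) and (a 1.1-fold higher number from compound 2 to compound 3 (0.05 log units; within the scatter)). All of them stay within the scatter, although none adds a single fluoro to an otherwise unchanged ring. No shift beyond the scatter is therefore expected in this assay for this small change. The estimated step is small (a 1.2-fold lower number from compound 3 to compound 4 (0.06 log units; within the scatter)). Compound 4 is estimated at 17000 nM (expected range 8000 nM to 35000 nM).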

Compound 4, half-maximal inhibitory concentration: 11200 nM
The estimate for compound 4 lay 1.5-fold (0.18 log units) above the measured number; the measured number falls inside the stated range.
By their numbers in this assay, from the lowest: compounds 4, 1, 2 and 3 (each within the scatter of the next).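

Unlike the earlier swaps, this step adds a single fluoro to an otherwise unchanged ring, and in this assay that addition reads as a 1.8-fold lower number from compound 3 to compound 4 (0.25 log units; within the scatter). The swaps from the other two aryl groups to 2,3,5-trifluorophenyl read the same way, as a 1.6-fold lower number from compound 2 to compound 4 (0.20 log units; within the scatter) and a 1.5-fold lower number from compound 1 to compound 4 (0.17 log units; within the scatter), so all four aryl groups stand level in this assay and this position tolerates one more fluoro without a change that can be told from the scatter. Nothing measured here speaks to what lies behind this result. Every aryl group shown carries fluorine, so a plain phenyl or a ring bearing an amine or a carboxylic acid remains open. From the compounds shown here alone, the rest of the core is the same in all four compounds, so the effect of changes there also remains open.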